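Benzyloxy in Place of Phenylethenyl on the Shared Core

The compounds below may be only part of what the source reports. "The series", "measured", "known", "first", "only" and "open" are said of these compounds alone.

Measured in an assay on isolated protein with metabotropic glutamate receptor 2 (Homo sapiens) as the target; on this read-out higher numbers stand for an effect only at larger amounts of compound and lower numbers for an effect already at smaller amounts:
Compound 1 `CCS(=O)(=O)N(Cc1cccnc1)c1ccc(C(O)c2ccccc2)cc1` gives > 30000 nM, a limit.
Compound 2 `C=C(c1ccccc1)c1cccc(N(Cc2cccnc2)S(=O)(=O)CC)c1` gives 200 nM.
Compound 3 `CCS(=O)(=O)N(Cc1cccnc1)c1ccc(C(F)c2ccccc2)cc1` gives > 30000 nM, a limit.

For the measured compounds named here, compound 2 is the only compound with a number; the two others sit at the limit of > 30000 nM in this assay, at which 2 of the 3 values shown sit, which is a limit, not a measured value. The step that the two limits leave unreadable from compound 1 to compound 3 therefore has no readable size. Compound 4 `CCS(=O)(=O)N(Cc1cccnc1)c1cccc(OCc2ccccc2)c1` differs from compound 2 by benzyloxy in place of 1-phenylethenyl on an aromatic carbon. Going by the values given here, no measured step touches that part of the shared core, so nothing sets a size or a direction for the change. For compound 4 a value of 1500 nM is expected, with a range from 200 nM to 15000 nM. The step of a 7.5-fold higher number from compound 2 to compound 4 (0.88 log units; beyond the scatter) thus expected is a modest loss, with wide uncertainty.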

Compound 4, half-maximal effective concentration: 440 nM
Beside the measured number, compound 4's estimate is 3.4-fold (0.53 log units) above it, and the stated range covers the measured number.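

In this assay, putting benzyloxy in place of 1-phenylethenyl gives a 2.2-fold higher number from compound 2 to compound 4 (0.34 log units; beyond the scatter), the first readable size for a change at this aromatic carbon. The number stays measurable with a group of the same heavy-atom count and the same carbon ring, now holding an oxygen and no double bond outside the ring. Nothing shown here explains the step.

Going by these compounds, whether an amine linking the phenyl ring at this carbon would give a similar number stays open. So does the effect of a longer chain between that ring and the shared core.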